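Swapping the aryl group on the shared pyrazole core

The source may hold more compounds than are shown below. What is called first, only, known or untested is meant among the compounds shown, and "the series" means these compounds.

Measured compounds:
- Compound 1, `COc1ccc(-c2c(C)nn(-c3nc(-c4ccc(Cl)c(Cl)c4)c(SC(C)C)s3)c2C(=O)O)cc1`: 2100 nM
- Compound 2, `Cc1nn(-c2nc(-c3ccc(Cl)c(Cl)c3)c(SC(C)C)s2)c(C(=O)O)c1-c1cncc(C#N)c1`: 20000 nM

In a functional assay on BJAB cells (Homo sapiens) for antiproliferative activity, with a stated time of 4 days (on this read-out higher numbers stand for an effect only at larger amounts of compound and lower numbers for an effect already at smaller amounts), compound 1 gives 2100 nM. In this assay compound 2 gives 20000 nM, the highest of the two numbers shown, and its only neighbour is compound 1, reached by the step of a 9.5-fold higher number from compound 1 to compound 2 (0.98 log units; beyond the scatter).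

Compound 3, `Cc1nn(-c2nc(-c3ccc(Cl)c(Cl)c3)c(SC(C)C)s2)c(C(=O)O)c1-c1cccc(C(F)(F)F)c1`, has not yet been measured. It differs from compound 2 in one place: 3-(trifluoromethyl)phenyl in place of 5-cyanopyridin-3-yl on an aromatic carbon. Within the data shown here, the only measured step that bears on this position is the one from compound 1 to compound 2, which was a 9.5-fold higher number from compound 1 to compound 2 (0.98 log units; beyond the scatter) and thus beyond the scatter. Because that step a 9.5-fold higher number from compound 1 to compound 2 (0.98 log units; beyond the scatter) shows a large swing at this site, compound 3 is expected to move again, in the downward direction, landing nearer to compound 1 than to compound 2. The expected step from compound 2 to compound 3 is a 5.7-fold lower number from compound 2 to compound 3 (0.76 log units; beyond the scatter). For compound 3 the estimate in this assay is 3500 nM, with a range from 1000 nM to 12000 nM.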

Compound 3, half-maximal effective concentration: 22000 nM
Estimate against measurement, compound 3: 6.3-fold (0.80 log units) below; the whole stated range lies below it.
By their numbers in this assay, from the lowest: compound 1; then compounds 2 and 3 (each within the scatter of the next).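

In this assay, the exchange on this aromatic carbon gives a 1.1-fold higher number from compound 2 to compound 3 (0.04 log units; within the scatter), so compound 2 and compound 3 cannot be told apart, even though 3-(trifluoromethyl)phenyl shares neither the ring nitrogen nor the nitrile of 5-cyanopyridin-3-yl. Measured against the 4-methoxyphenyl group, the new group gives a 10-fold higher number from compound 1 to compound 3 (1.02 log units; beyond the scatter), a step of about the same size as the one seen with 5-cyanopyridin-3-yl, which leaves compound 1 alone at the lower end among these three compounds. No measurement here accounts for this outcome.

From the compounds shown here alone, what remains open is whether the lower number of compound 1 belongs to the methoxy group itself or to some wider feature of that aryl group. An unsubstituted phenyl ring, or a phenyl ring bearing a hydroxy group or an amine, would help to separate these possibilities.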